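The compounds below may be only part of what the source reports. "The series", "measured", "known", "first", "only" and "open" are said of these compounds alone.

Compound 1 `CCc1ccccc1Nc1ncc2cc(Oc3ccnc(C(=O)NC)c3)ccc2n1` is measured in an ADME assay on Caco-2 cells (Homo sapiens) for permeability, in the apical to basolateral direction (on this read-out lower numbers stand for lower permeability and higher numbers for higher permeability), where compound 1 gives < 1 10^-6 cm/s, which is a limit of the assay rather than a number. Compound 2 `CNC(=O)c1cc(Oc2ccc3nc(Nc4ccc(F)cc4)ncc3c2)ccn1` also reaches only a limit in this assay, giving < 1 10^-6 cm/s. Compound 3 `CNC(=O)c1cc(Oc2ccc3nc(Nc4ccc(Br)cc4)ncc3c2)ccn1` likewise gives < 1 10^-6 cm/s in this assay, again a limit. Because (the limit of < 1 10^-6 cm/s in this assay, at which 3 of the 3 values shown sit), none of the three values can be placed above or below another, and the steps a step that the two limits leave unreadable from compound 1 to compound 2 and a step that the two limits leave unreadable from compound 1 to compound 3 are of no readable size. The change from compound 1 to compound 4 `CNC(=O)c1cc(Oc2ccc3nc(Nc4ccc(OC)cc4)ncc3c2)ccn1` is 4-methoxyphenyl in place of 2-ethylphenyl on a nitrogen on an aromatic ring. The measured steps that bear on it are those two, each replacing the 2-ethylphenyl with another phenyl on a nitrogen on an aromatic ring, and each left unreadable by the limits. No direction or size can therefore be read for this assay; the expectation is simply that compound 4 stays at the limit as well. Compound 4 is estimated at 0.5 10^-6 cm/s, ranging from 0.1 10^-6 cm/s to 2 10^-6 cm/s, which would be a step that the limit leaves unreadable from compound 1 to compound 4 that is expected to lie within the scatter.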

Compound 4, apparent permeability: < 1 10^-6 cm/s
Compound 4 was reported as a limit; the forecaster's own chance of this, stated with the estimate: 75%; the middle value is on the limit's open side.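

In this assay compound 4 gives < 1 10^-6 cm/s, which is a limit. No step from compound 1, compound 2 or compound 3 to compound 4 can be read, because the values coincide at the limit: the limit of < 1 10^-6 cm/s in this assay, at which 4 of the 4 values shown sit.

The compounds shown leave open how these four compare in this assay.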